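A few compounds are considered here, and "the series" means these few. Any claim that something is new, unique, unknown or untested is made for them only; others in the source may bear on it.

Measured so far:
Compound 1, `CC(=O)OCC(CCn1cc(C#Cc2cc(F)cc(F)c2)c(=O)n(C(=O)c2ccccc2)c1=O)COC(C)=O`: 28900 nM
Compound 2, `CC(=O)OCC(CCn1cc(C#CCCCCl)c(=O)n(C(=O)c2ccccc2)c1=O)COC(C)=O`: 21000 nM

Both numbers come from a functional assay on MCF7 cells (Homo sapiens) for antiproliferative activity, read by MTT assay, with a stated time of 72 h; on this read-out lower numbers stand for stronger inhibition and higher numbers for weaker inhibition. Among the two values, compound 1 stands highest, and its nearest neighbour is compound 2, reached by a 1.4-fold lower number from compound 1 to compound 2 (0.14 log units; within the scatter), a step that the assay cannot tell apart from repeat noise. Compound 3, `CC(=O)OCC(CCn1cc(C#CC(C)(C)C)c(=O)n(C(=O)c2ccccc2)c1=O)COC(C)=O`, is not yet measured. It differs from compound 1 in one place: tert-butyl in place of 3,5-difluorophenyl on a triple-bonded carbon. Among the compounds with values here, the only measured step that bears on this one is the step from compound 1 to compound 2, where a 3-chloropropyl replaced the same 3,5-difluorophenyl on the same triple-bonded carbon, and the number moved by a 1.4-fold lower number from compound 1 to compound 2 (0.14 log units; within the scatter). A tert-butyl at that position is expected to behave in the same way, so the step of a 1.2-fold lower number from compound 1 to compound 3 (0.06 log units; within the scatter) is estimated to stay within the scatter, in no particular direction. Compound 3 is therefore expected to give about 25000 nM in this assay, within a range from 10000 nM to 60000 nM.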

Compound 3, half-maximal inhibitory concentration: 67100 nM
Compound 3: the middle estimate sits 2.7-fold (0.43 log units) below what was measured, outside the stated range (above it).
By their numbers in this assay, from the lowest: compounds 2 and 1 (each within the scatter of the next); then compound 3.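

In this assay, the group on this triple-bonded carbon can shift the number after all: tert-butyl gives a clear rise over 3,5-difluorophenyl (a 2.3-fold higher number from compound 1 to compound 3 (0.37 log units; beyond the scatter)) and over 3-chloropropyl (a 3.2-fold higher number from compound 2 to compound 3 (0.50 log units; beyond the scatter)), whereas the step between those two earlier groups could not be told from noise. Having a ring does not sort these three compounds, since compound 2 and compound 3 both lack one, yet only compound 3 stands apart. No measurement here explains why tert-butyl differs from the other two groups.

The compounds shown leave open whether a plain phenyl, an unbranched butyl chain or a chain ending in an amine on this carbon would group with compound 1 and compound 2 or with compound 3. They also leave open whether the same order holds in other cell lines.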